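Oxetanyl for Cyclobutyl at the Ortho Position of the Biaryl

A few compounds are considered here, and "the series" means these few. Any claim that something is new, unique, unknown or untested is made for them only; others in the source may bear on it.

Measured compounds:
Compound 1, `CSc1cnc(-c2ccccc2C(C)C)nc1NCc1ccc(-c2cccnc2)cc1`: 110 nM
Compound 2, `Cc1cnc(-c2ccccc2C(C)C)nc1NCC1CCN(c2cccnc2)CC1`: 80 nM
Compound 3, `Cc1cnc(-c2ccccc2C2CCC2)nc1NCc1ccc(-n2ccnn2)cc1`: 180 nM

Three compounds sharing one core have been run in an assay on a protein complex for inhibition of ubiquitin carboxyl-terminal hydrolase 1/WD repeat-containing protein 48 (Homo sapiens), read by fluorescence; on this read-out higher numbers stand for weaker inhibition and lower numbers for stronger inhibition. Compound 1 gives 110 nM and compound 2 gives 80 nM. Compound 3 gives 180 nM, the highest of the three numbers; its gap to compound 1 lies within the scatter of this assay, while its gap to compound 2 lies beyond it, so compound 3 clearly inhibits less strongly than compound 2 and cannot be separated from compound 1.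

Compound 4, `Cc1cnc(-c2ccccc2C2COC2)nc1NCc1ccc(-n2ccnn2)cc1`, has not been measured. It differs from compound 3 in one place: oxetan-3-yl in place of cyclobutyl on an aromatic carbon. The change sits ortho to a large group on the phenyl ring attached to the core. Among the measured compounds shown here, no measured pair in this set tracks the same exchange, so the step from compound 3 to compound 4 cannot be read off any neighbour.

In this assay compound 4 is expected to land close to compound 3, with a step of a 1.4-fold higher number from compound 3 to compound 4 (0.14 log units; within the scatter) toward a somewhat higher number, within or at the edge of the scatter. The estimate for compound 4 is 250 nM, with a range from 100 nM to 650 nM.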

Compound 4, half-maximal inhibitory concentration: "not active" (no number reported)
Compound 4: no number reported, so the estimate cannot be set against anything.
By their numbers in this assay, from the lowest: compounds 2, 1 and 3 (each within the scatter of the next, the first and the last beyond it).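

In this assay, among the compounds shown here, compound 4 is reported as "not active" with no number, so no step from compound 3 to compound 4 can be read. No measurement shown here accounts for this result. The compounds shown leave open how far oxetan-3-yl in place of cyclobutyl moves the number, and whether that exchange acts alike elsewhere.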